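The source may hold more compounds than are shown below. What is called first, only, known or untested is meant among the compounds shown, and "the series" means these compounds.

Measured so far in an assay on HEK293 cells for inhibition of transient receptor potential cation channel subfamily M member 8 (Homo sapiens), read by FLIPR, with stated times of 5 min and 3 min; on this read-out higher numbers stand for weaker inhibition and lower numbers for stronger inhibition:
compound 1 `CCn1nnc(-c2sc(-c3cccc(N)c3)nc2O)n1` gives 61 nM
compound 3 `CCn1nnc(-c2sc(-c3cccc(OC)c3)nc2O)n1` gives 245 nM
compound 2 `CCOC(=O)c1sc(-c2ccccc2)nc1OC` gives only a limit of the assay, > 100000 nM

Compound 2 and compound 3 carry different cores; the difference between the two cores is not broken down here. From compound 3 to compound 1 the change is amino in place of methoxy on an aromatic carbon, and it gave a 4.0-fold lower number from compound 3 to compound 1 (0.60 log units; beyond the scatter). The same kind of change, (amino in place of methoxy on an aromatic carbon), leads from compound 2 to compound 4 `CCOC(=O)c1sc(-c2ccccc2)nc1N`, which is still to be measured in this assay. The place is not the same: in compound 1 the amino stands on an aromatic carbon of a six-membered aromatic ring of carbon only, meta to a large group, whereas in compound 4 it stands on an aromatic carbon of a five-membered aromatic ring with 1 nitrogen and 1 sulfur, next to the ring nitrogen and next to the ring atom that bears an ethoxycarbonyl group. Since compound 2 sits at the limit of > 100000 nM in this assay, at which 1 of the 3 values shown sits, compound 4 is expected to stay weak, with an estimated step of an at least 1.6-fold lower number from compound 2 to compound 4 (0.22 log units; that floor lies within the scatter). The estimate for compound 4 in this assay is 60000 nM, expected between 10000 nM and 300000 nM, and a limit rather than a number is likely again.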

Compound 4, half-maximal inhibitory concentration: > 100000 nM
Compound 4 gave a limit, no number; the forecaster's own chance of this, stated with the estimate: 65%; middle value at least 1.6-fold (0.22 log units) from the limit.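

Within the data shown here, compound 4, like compound 2, gives only a limit of the assay and no number, so no step between the two can be read: the limit of > 100000 nM in this assay, at which 2 of the 4 values shown sit.

The compounds shown leave open whether amino in place of methoxy changes inhibition at all on the core of compound 2, and whether any compound with that core gives a readable number.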